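A Chloro to Fluoro Exchange on an Aromatic Ring

The source may report more compounds than this note shows. Statements on the series, on what has been measured and on what is new or still open speak of the compounds shown alone.

Compound 1 `Cc1cc(=O)c2c(O)c(CN3CC(O)CC3C(=O)O)c(O)c([C@H]3CCN(C)C[C@H]3O)c2o1` gives 28% in growth inhibition
Compound 2 `CN1CC[C@H](c2c(O)cc(O)c3c(=O)cc(/C=C/c4cccc(Cl)c4)oc23)[C@H](O)C1` gives 35% in growth inhibition

In a functional assay on HL-60 cells (Homo sapiens) for inhibition, read by MTT assay, with a stated time of 48 h, tested at 10 uM (a higher number here means more inhibition of growth at the concentration tested, a lower number less inhibition of growth), compound 2 gives 35% and stands within the usual scatter of compound 1, which gives 28% here. Compound 3 `CN1CC[C@H](c2c(O)cc(O)c3c(=O)cc(/C=C/c4cccc(F)c4)oc23)[C@H](O)C1` has not yet been measured. It differs from compound 2 in one place: fluoro in place of chloro on an aromatic carbon on an aromatic carbon of a six-membered aromatic ring of carbon only, meta to a large group, so that 3-chlorophenyl becomes 3-fluorophenyl. Going by the values given here, no measured pair shows what a single exchange does in this assay, so the only guide is compound 2 at 35% and no change beyond the scatter is expected. The expected difference is a number 3 percentage points lower from compound 2 to compound 3 (within the scatter) and no more than that. Compound 3 is estimated at 32%, within an expected range from 16% to 50% when tested.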

Compound 3, percent growth inhibition at one concentration: 60%
Estimate against measurement, compound 3: 28 percentage points below, outside the stated range (above it).
By their numbers in this assay, from the lowest: compounds 1 and 2 (each within the scatter of the next); then compound 3.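

In this assay, the move from 3-chlorophenyl to 3-fluorophenyl gives a number a number 25 percentage points higher from compound 2 to compound 3 (beyond the scatter), so the halogen at this place on the aromatic ring is not a silent detail of the series. Going by these compounds alone, compound 1 and compound 2 offered no single exchange to read, and only this pair shows that one atom changed here can shift growth inhibition beyond the scatter. No measurement at hand explains the step.

The compounds shown leave open whether the higher number is particular to fluoro or would also appear with hydrogen, a methoxy group or a trifluoromethyl group at this same place. They also leave open whether a 3-fluorophenyl group would give a similar result with an amine or a carboxylic acid elsewhere on the shared core.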